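Methoxy Added Para on the Aryl Ether of Compound 2

The source may hold more compounds than are shown below. What is called first, only, known or untested is meant among the compounds shown, and "the series" means these compounds.

Compound 1 `NC1=NC2(CCSCC2)N(OCCCOc2ccc(Cl)c(Cl)c2)C(N)=N1` gives 88.4% in an assay on isolated protein for inhibition of Dihydrofolate reductase (Homo sapiens), read by spectrophotometry, using NADPH, with stated times of 5 s and 6 min, tested at 5 uM; a lower number here means a weaker effect, a higher number a stronger effect of the compound at the concentration tested. Compound 2 `NC1=NC2(CCOCC2)N(OCCCOc2ccccc2)C(N)=N1` reaches in this assay a limit of the assay rather than a number, > 90%. Compound 2 thus sits at the limit of > 90% in this assay, at which 1 of the 2 values shown sits. As far as these compounds go, compound 3 `COc1ccc(OCCCON2C(N)=NC(N)=NC23CCOCC3)cc1` remains untested in this assay and differs from compound 2 by methoxy in place of hydrogen on an aromatic carbon. Among the measured compounds shown here, since the two measured compounds differ in more than one place, no single step is known; the change is expected to alter inhibition by no more than the usual scatter. Compound 3 is expected to give 90% in this assay, between 75% and 100%. The expected step is a number no higher from compound 2 to compound 3 (the limit leaves the size open).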

Compound 3, a percentage reported as inhibition, at one concentration (the size of the read-out at that concentration, not a potency): > 90%
Compound 3: a limit, no number; the forecaster's own chance of this, stated with the estimate: 55%; the middle value lies on the limit itself.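

No step can be read between compound 2 and compound 3, as each gives a limit rather than a number: the limit of > 90% in this assay, at which 2 of the 3 values shown sit.

What methoxy in place of hydrogen does to inhibition in this assay stays open among the compounds shown.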